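The compounds below may be only part of what the source reports. "The series", "measured", "known", "first", "only" and "open" are said of these compounds alone.

Measured in an ADME assay on CEM-SS cells (Homo sapiens) for cytotoxicity, read by XTT assay, with a stated time of 6 days (a lower number here means that less compound is tolerated, a higher number that more compound is tolerated), all three values being limits and not numbers:
- compound 1 `CCCC(=O)OCSc1ccccc1C(=O)NCCC(N)=O`: > 100 uM
- compound 2 `CCCC(=O)OCSc1ccc(OC(F)(F)F)cc1C(=O)NC(C)(C)C(N)=O`: < 56.1 uM
- compound 3 `CCCC(=O)OCSc1ccc(OC)cc1C(=O)NCCC(N)=O`: > 100 uM

Compound 1 stands at the limit of > 100 uM in this assay, at which 2 of the 3 values shown sit. Its position is therefore known only as a limit.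

Compound 4 `CCCC(=O)OCSc1ccccc1C(=O)NCC(N)=O` carries carbamoyl in place of carbamoylmethyl on a saturated chain carbon bound to an amide-type nitrogen. The side chain thus reads carbamoylmethyl instead of 2-carbamoylethyl.

Within the data shown here, the only measured step is a step that the two limits leave unreadable from compound 1 to compound 3. It concerns a different place, and its size cannot be read, so it gives no guide to this change. No step beyond the scatter is expected in this assay, in either direction. The expected change is a number no higher from compound 1 to compound 4 (the limit leaves the size open). For compound 4 the estimate is 100 uM, with an expected range of 50 uM to 200 uM.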

Compound 4, half-maximal toxic concentration: > 100 uM
Compound 4: a limit, no number; the forecaster's own chance of this, stated with the estimate: 75%; the middle value sits exactly at the limit.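

In this assay compound 1 gives > 100 uM, a limit. Among these compounds, compound 4 gives > 100 uM, also a limit, and no step between compound 1 and compound 4 can be read. The compounds shown leave open whether carbamoyl in place of carbamoylmethyl shifts the tolerated concentration at all.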